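The compounds below may be only part of what the source reports. "The series", "measured", "known", "first", "only" and "open" are said of these compounds alone.

Compound 1 `COc1ccc(Cn2cc(CNC(=O)c3cn(-c4ccccc4)nc3-c3ccc(F)cc3)nn2)cc1OC` carries a 3,4-dimethoxyphenyl on the saturated chain carbon bound to an aromatic nitrogen, and in a functional assay on MIA PaCa-2 cells (Homo sapiens) for antiproliferative activity, read by sulforhodamine B assay, with a stated time of 48 h (on this read-out higher numbers stand for weaker inhibition of growth and lower numbers for stronger inhibition of growth), compound 1 returns only a limit, > 100000 nM, which is the limit of > 100000 nM in this assay, at which 1 of the 3 values shown sits. Compound 2 `COc1cc(Cn2cc(CNC(=O)c3cn(-c4ccccc4)nc3-c3ccc(F)cc3)nn2)cc(OC)c1` differs from compound 1 by 3,5-dimethoxyphenyl in place of 3,4-dimethoxyphenyl on a saturated chain carbon bound to an aromatic nitrogen, and in this assay compound 2 gives 190 nM; the step is an at least 520-fold lower number from compound 1 to compound 2 (2.72 log units; beyond the scatter). Compound 3 `COc1ccc(-c2nn(-c3ccccc3)cc2C(=O)NCc2cn(Cc3ccc(OC)c(OC)c3)nn2)cc1` differs from compound 1 in its core by methoxy in place of fluoro on an aromatic carbon, and in this assay compound 3 gives 16300 nM, the step being an at least 6.1-fold lower number from compound 1 to compound 3 (0.78 log units; beyond the scatter). Compound 4 `COc1ccc(-c2nn(-c3ccccc3)cc2C(=O)NCc2cn(Cc3cc(OC)cc(OC)c3)nn2)cc1` is not yet measured; it differs from compound 3 by 3,5-dimethoxyphenyl in place of 3,4-dimethoxyphenyl on a saturated chain carbon bound to an aromatic nitrogen, the same change that separates compound 1 from compound 2. Because that change produced an at least 520-fold lower number from compound 1 to compound 2 (2.72 log units; beyond the scatter), a large drop is expected for compound 4 as well, though the earlier step rests on a limit and its true size is not known. Compound 4 is therefore estimated at 40 nM, between 8 nM and 300 nM, a step of a 410-fold lower number from compound 3 to compound 4 (2.61 log units; beyond the scatter) that is expected to be large.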

Compound 4, concentration for 50% growth inhibition: 5800 nM
Beside the measured number, compound 4's estimate is 150-fold (2.16 log units) below it; the whole stated range lies below it.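

Moving to 3,5-dimethoxyphenyl lowers the number in this assay on both cores, but on the core of compound 3 it gives only a 2.8-fold lower number from compound 3 to compound 4 (0.45 log units; beyond the scatter), so the direction carries over and the size does not: the same change on two cores in this assay, an at least 520-fold lower number (2.72 log units; beyond the scatter) from compound 1 to compound 2 and a 2.8-fold lower number (0.45 log units; beyond the scatter) from compound 3 to compound 4, at least 180-fold (2.27 log units) apart, beyond the scatter of two such steps

Methoxy in place of fluoro does not carry over either, since its direction turns round on the 3,5-dimethoxyphenyl side, with a 31-fold higher number from compound 2 to compound 4 (1.48 log units; beyond the scatter): the same change on two cores in this assay, an at least 6.1-fold lower number (0.78 log units; beyond the scatter) from compound 1 to compound 3 and a 31-fold higher number (1.48 log units; beyond the scatter) from compound 2 to compound 4, at least 180-fold (2.27 log units) apart, beyond the scatter of two such steps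

Compound 1 stands at a limit of the assay, so these gaps are minimum sizes and the data show neither their true extent nor why the two groups depend on each other: the limit of > 100000 nM in this assay, at which 1 of the 4 values shown sits.

The compounds shown leave open whether the strong effect of 3,5-dimethoxyphenyl in compound 2 would persist with a chloro or a trifluoromethyl group in place of fluoro on that aromatic carbon. They also leave open how an ethoxy group in place of each methoxy on the benzyl ring would behave on either core.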